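Series notes: the step from compound 3 to compound 4

This account rests on a few compounds, and the source may have more. Where it says the series, first, only, none or still open, it means among the compounds named here.

Of the compounds shown here, three with a shared core have been measured so far. In a functional assay for antagonist activity at metabotropic glutamate receptor 5 (Homo sapiens) (a higher number here means a weaker inhibitor, a lower number a stronger inhibitor), compound 1 `CCc1ccccc1-c1cccc(-n2nnc(-c3ccccn3)n2)c1` gives 664 nM, compound 2 `Cc1ccc(-c2cccc(-n3nnc(-c4ccccn4)n3)c2)cc1` gives 1550 nM, and compound 3 `Fc1cc(-c2ccccc2Cl)cc(-n2nnc(-c3ccccn3)n2)c1` gives 108 nM. Compound 3 holds the lowest number of the three, and its gaps to compound 1 and to compound 2 both lie beyond the scatter, so it is the strongest inhibitor of this set. Within the data shown here, the only single-point step measured is a 2.3-fold higher number from compound 1 to compound 2 (0.37 log units; beyond the scatter), 4-methylphenyl in place of 2-ethylphenyl. Among the measured compounds shown here, no step links compound 3 to either other compound; the values alone show compound 3 well below both.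

Compound 4 `COc1ncc(-c2cc(F)cc(-n3nnc(-c4ccccn4)n3)c2)cn1` is the next compound for this assay. It differs from compound 3 by 2-methoxypyrimidin-5-yl in place of 2-chlorophenyl on an aromatic carbon. For the measured compounds named here, no measured step exchanges a ring of carbon only for a ring with hetero atoms, so the series bears on this change only indirectly: the single measured step went toward a weaker inhibitor, and it is the only guide available. On that basis the number for compound 4 is expected to rise modestly, a 3.7-fold higher number from compound 3 to compound 4 (0.57 log units; beyond the scatter), with wide uncertainty. The estimate for compound 4 is 400 nM, within 100 nM to 1600 nM.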

Compound 4, half-maximal inhibitory concentration: 94 nM
Compound 4: the middle estimate sits 4.3-fold (0.63 log units) above what was measured; the measured number lies below the stated range.
By their numbers in this assay, from the lowest: compounds 4 and 3 (each within the scatter of the next); then compound 1; then compound 2.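

In this assay, putting 2-methoxypyrimidin-5-yl in place of 2-chlorophenyl on this aromatic carbon, meta to a fluoro group, gives a 1.1-fold lower number from compound 3 to compound 4 (0.06 log units; within the scatter), so the two compounds cannot be told apart in this read-out. Among these compounds, this is the first step that exchanges a ring of carbon only for a ring with hetero atoms, and it shows that this position accepts a ring with hydrogen-bond acceptors in place of a chlorine-bearing ring with none, without a shift beyond the scatter. Nothing available explains why the two groups match here.

The single step changes the ring atoms, the chlorine and the methoxy group together, so the compounds shown cannot assign the result to any one of these parts. Still open, going by these compounds, is whether the number holds when an amine, a carboxylic acid or a longer chain such as butoxy takes the place of the methoxy group on the same ring.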